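Swapping a methoxy for an oxetanyl amine on a shared core

The compounds below may be only part of what the source reports. "The series", "measured", "known", "first", "only" and "open" are said of these compounds alone.

Of the compounds shown here, two sharing one core have been tested in a functional assay on cells for antagonist activity at C-C chemokine receptor type 4 (Homo sapiens), read by GTPgammaS binding; a lower number here means a stronger inhibitor, a higher number a weaker inhibitor. Compound 1 `COCCn1nc(OC)c2c(NS(=O)(=O)c3cccc(Cl)c3Cl)ncnc21` gives 316 nM. Compound 2 `COc1nc(NS(=O)(=O)c2cccc(Cl)c2Cl)c2c(OC)nn(C)c2n1` gives 794 nM, the higher of the two numbers, so it is the weaker inhibitor of the pair; the gap to compound 1 is beyond the usual scatter. These two compounds differ in more than one place, so no single structural change can be tied to that gap.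

Compound 3 `COc1nn(C)c2nc(NC3COC3)nc(NS(=O)(=O)c3cccc(Cl)c3Cl)c12` has not yet been measured. It differs from compound 2 in one place: (oxetan-3-yl)amino in place of methoxy on an aromatic carbon. Going by the values given here, no measured pair here shows what such a change does on this core, so there is no step to lean on.

With nothing to anchor the direction, the expected step of a 1.4-fold lower number from compound 2 to compound 3 (0.15 log units; within the scatter) is small and could fall either way, probably not beyond the scatter. Compound 3 is therefore estimated at 560 nM, with a likely range from 140 nM to 2200 nM; a reading near compound 2 would be no surprise.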

Compound 3, half-maximal inhibitory concentration: 10000 nM
For compound 3 the middle estimate is 18-fold (1.25 log units) below the measured one; the measured number lies above the stated range.
By their numbers in this assay, from the lowest: compound 1; then compound 2; then compound 3.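

In this assay, putting (oxetan-3-yl)amino in place of methoxy on the aromatic carbon between two ring nitrogen atoms gives a 13-fold higher number from compound 2 to compound 3 (1.10 log units; beyond the scatter), a large loss of inhibition and well beyond the scatter. Going by these compounds alone, this is the first single-place change measured on this core, and it shows that this position does not accept every group: one swap, with the rest of the molecule unchanged, is enough to weaken the compound sharply. The entering group differs from methoxy in several ways at once, as it is larger, carries a four-membered ring and brings a hydrogen-bond donor, and no measurement here explains the loss or ties it to any one of these differences.

The compounds shown leave open which part of the (oxetan-3-yl)amino group goes with the loss, the amine nitrogen or the oxetane ring. A methylamino group on the same carbon would keep the amine nitrogen without the ring, and an oxetan-3-yloxy group would keep the ring without that nitrogen, so the two together could begin to separate these parts.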